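Branched all-carbon chain replacing the butoxyethyl chain

The source may hold more compounds than are shown below. What is called first, only, known or untested is meant among the compounds shown, and "the series" means these compounds.

The measured compounds, all in a functional assay on ileum for inhibition of histamine H1 receptor (Cavia porcellus); on this read-out higher numbers stand for weaker inhibition and lower numbers for stronger inhibition:
compound 1 `CCCCCCCn1c(N2CCN(C)CC2)nc2ccccc21` gives 150 nM;
compound 2 `CN1CCN(c2nc3ccccc3n2CCOCCO)CC1` gives 42 nM;
compound 3 `CCCCOCCn1c(N2CCN(C)CC2)nc2ccccc21` gives 38 nM.

Compound 3 has the lowest of the three numbers in this assay, though compound 2 lies within the scatter of it; only compound 1 stands clearly apart. Compound 4 `CCCC(C)Cn1c(N2CCN(C)CC2)nc2ccccc21` is not yet measured. It differs from compound 3 in this way: 1-methylbutyl in place of butoxymethyl on a saturated chain carbon bound to an aromatic nitrogen.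

Going by the values given here, two measured steps bear on the change. Exchanging pentyl for an oxygen-bearing chain gave a 3.6-fold lower number from compound 1 to compound 2 (0.55 log units; beyond the scatter) and a 3.9-fold lower number from compound 1 to compound 3 (0.60 log units; beyond the scatter), both beyond the scatter and both in the same direction, while the step of a 1.1-fold lower number from compound 2 to compound 3 (0.04 log units; within the scatter) stayed within the scatter. Among the compounds with values here, compound 4 carries no oxygen in its chain at all, so the step from compound 3 to compound 4 runs the other way from the step from compound 1 to compound 3, although compound 4 is not simply compound 1 again: its chain is shorter and branched, and no measured compound tells how that branch counts. The expected outcome is a move back toward the number of compound 1, estimated as a 2.6-fold higher number from compound 3 to compound 4 (0.42 log units; beyond the scatter). Compound 4 is therefore expected to give about 100 nM, with a range from 40 nM to 300 nM.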

Compound 4, half-maximal inhibitory concentration: 500 nM
Compound 4: the middle estimate sits 5.0-fold (0.70 log units) below what was measured; the whole stated range lies below it.
By their numbers in this assay, from the lowest: compounds 3 and 2 (each within the scatter of the next); then compound 1; then compound 4.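

In this assay, the change to 2-methylpentyl does not return the number to the level of compound 1 but goes past it, with 1-methylbutyl in place of hexyl giving a 3.3-fold higher number from compound 1 to compound 4 (0.52 log units; beyond the scatter). The two oxygen-bearing chains, whose values lie within the scatter of each other, both stand far from this branched all-carbon chain, as shown by a 13-fold higher number from compound 3 to compound 4 (1.12 log units; beyond the scatter) and a 12-fold higher number from compound 2 to compound 4 (1.08 log units; beyond the scatter), both large steps. The earlier compounds shown here held a single all-carbon chain at this place, on a saturated chain carbon bound to an aromatic nitrogen, and the new result shows that two all-carbon chains can themselves differ there by a step beyond the scatter.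

Compound 1 and compound 4 differ in both chain length and branching, so the compounds shown leave open which of the two separates them, and an unbranched pentyl chain, or an amine in the place of the ether oxygen of compound 3, would bear on that and on the role of the oxygen. Nothing at hand accounts for the size of these steps.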